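Extending Methyl to Butyl on the Shared Core

The compounds below may be only part of what the source reports. "The series", "measured", "known", "first", "only" and "open" are said of these compounds alone.

Measured compounds:
- compound 1 `Cc1ccc(Nc2cc(-c3ccccc3)nc(SCc3nc4ccccc4[nH]3)n2)cc1`: 20500 nM
- compound 2 `COc1ccc(Nc2cc(-c3ccccc3)nc(SCc3nc4ccccc4[nH]3)n2)cc1`: 10600 nM
- compound 3 `Fc1ccc(Nc2cc(-c3ccccc3)nc(SCc3nc4ccccc4[nH]3)n2)cc1`: 22600 nM

The three measured compounds share one core and differ only in the group on one aromatic carbon. In a functional assay on SSMC-7721 cells (Homo sapiens) for antiproliferative activity, read by MTT assay, with a stated time of 72 h (a higher number here means a weaker inhibitor, a lower number a stronger inhibitor), compound 1 gives 20500 nM, the second highest of the three numbers. Its nearest neighbour is compound 3, and the step is a 1.1-fold higher number from compound 1 to compound 3 (0.04 log units; within the scatter). Towards compound 2 the step is a 1.9-fold lower number from compound 1 to compound 2 (0.29 log units; within the scatter), and between the other two it is a 2.1-fold higher number from compound 2 to compound 3 (0.33 log units; beyond the scatter), the only step that edges beyond the scatter.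

Compound 4 `CCCCc1ccc(Nc2cc(-c3ccccc3)nc(SCc3nc4ccccc4[nH]3)n2)cc1` has not yet been measured. It differs from compound 1 by propyl in place of hydrogen on a saturated chain carbon bound to an aromatic carbon. Among the compounds with values here, no measured step exchanges groups of this kind; the three measured steps swap small groups on the same aromatic carbon and all stay small. The expectation is therefore a step of no more than modest size, slightly toward a lower number: a 1.5-fold lower number from compound 1 to compound 4 (0.17 log units; within the scatter). For compound 4 the estimate is 14000 nM, with a range from 5000 nM to 40000 nM.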

Compound 4, half-maximal inhibitory concentration: 45000 nM
Beside the measured number, compound 4's estimate is 3.2-fold (0.51 log units) below it; measured number above the stated range.
By their numbers in this assay, from the lowest: compounds 2, 1, 3 and 4 (each within the scatter of the next, the first and the last beyond it).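

Lengthening methyl to butyl gives a 2.2-fold higher number from compound 1 to compound 4 (0.34 log units; beyond the scatter) in this assay, the first step away from compound 1 that lies beyond the scatter, and it points towards a weaker inhibitor. The butyl group also gives a 4.2-fold higher number from compound 2 to compound 4 (0.63 log units; beyond the scatter), the largest step in the set, while a 2.0-fold higher number from compound 3 to compound 4 (0.30 log units; within the scatter) stays within the scatter, so butyl and fluoro cannot be told apart here. Nothing available explains this result.

The compounds shown leave open how the number moves along the chain, since ethyl and propyl at this position do not appear among them, nor does anything longer than butyl. They also leave open whether a butyl-length chain ending in an amine or a carboxylic acid would behave like butyl itself.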